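Trading 3-nitrophenyl for 4-acetylphenyl on a shared core

The compounds below may be only part of what the source reports. "The series", "measured", "known", "first", "only" and "open" are said of these compounds alone.

Compound 1 `OC[C@H]1O[C@H](Oc2ccc(-c3ccccc3Cl)cc2Cl)[C@@H](O)[C@@H](O)[C@@H]1O`, compound 2 `OC[C@H]1O[C@H](Oc2ccc(-c3ccccc3)cc2Cl)[C@@H](O)[C@@H](O)[C@@H]1O` and compound 3 `O=[N+]([O-])c1cccc(-c2ccc(O[C@H]3O[C@H](CO)[C@@H](O)[C@H](O)[C@@H]3O)c(Cl)c2)c1` share a core and differ in a single aromatic group. In a physicochemical assay for lipophilicity, read by LC-MS, measured as octanol-water partition, with a stated time of 2 h, at pH 7.4, tested at 1 uM (on this read-out lower numbers stand for lower lipophilicity and higher numbers for higher lipophilicity), compound 1 gives 3.1, compound 2 gives 2.6 and compound 3 gives 2.4. Compound 3 therefore cannot be told apart from compound 2, while compound 1 stands clearly apart, with a number 0.70 log units lower from compound 1 to compound 3 (beyond the scatter).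

Compound 4 `CC(=O)c1ccc(-c2ccc(O[C@H]3O[C@H](CO)[C@@H](O)[C@H](O)[C@@H]3O)c(Cl)c2)cc1` keeps the core but carries 4-acetylphenyl in place of 3-nitrophenyl on an aromatic carbon. Going by the values given here, no measured step exchanges these two groups directly, so the evidence is indirect. Hydrogen in place of chloro gave a number 0.50 log units lower from compound 1 to compound 2 (beyond the scatter), a modest move. Nitro in place of hydrogen gave a number 0.20 log units lower from compound 2 to compound 3 (within the scatter), which shows that compound 3 keeps the number of compound 2 within the scatter.

From the compounds shown here alone, on that basis, no step beyond the scatter is expected in this assay, and the direction stays open. The estimated change is a number 0.10 log units higher from compound 3 to compound 4 (within the scatter). For compound 4, the estimated value is 2.5, with an expected range from 2 to 3.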

Compound 4, distribution coefficient: 2.1
Beside the measured number, compound 4's estimate is 0.40 log units above it; the measured number falls inside the stated range.
By their numbers in this assay, from the lowest: compounds 4, 3 and 2 (each within the scatter of the next, the first and the last beyond it); then compound 1.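

In this assay, putting 4-acetylphenyl in place of 3-nitrophenyl gives a number 0.30 log units lower from compound 3 to compound 4 (within the scatter) and so leaves the two groups unresolved at this position on the shared core, even though they differ in their atoms. Measured against compound 2, which has only hydrogen on that ring, the two groups read differently: nitro gave a number 0.20 log units lower from compound 2 to compound 3 (within the scatter) while acetyl gives a number 0.50 log units lower from compound 2 to compound 4 (beyond the scatter) and so clears the scatter, although compound 3 and compound 4 still cannot be told apart from each other. The full span of this small set also widens, with a number 1.00 log units lower from compound 1 to compound 4 (beyond the scatter) and the 2-chlorophenyl group at the top end.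

The compounds shown leave open whether an amine or a carboxylic acid on this ring would move the number beyond the scatter from compound 3. They also cannot separate the identity of the group from its place on the ring, as 3-nitrophenyl and 4-acetylphenyl differ in both.

No measurement shown here accounts for these numbers.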